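Removing the dimethylamino chain from compound 2

This account rests on a few compounds, and the source may have more. Where it says the series, first, only, none or still open, it means among the compounds named here.

Compound 1 `CN(/N=N/c1ccccc1)c1ccccc1` gives > 100000 nM in an ADME assay on BHK-21 cells (Mesocricetus auratus) for cytotoxicity, read by MTT assay, with a stated time of 96 h (on this read-out lower numbers stand for higher toxicity in this test and higher numbers for lower toxicity in this test), which is a limit of the assay and not a number. Among the compounds with values here, compound 2 `CN(C)CCCN(/N=N/c1cccc([N+](=O)[O-])c1)c1ccccc1` gives 54000 nM, the only actual number so far. Compound 3 `CN(/N=N/c1cccc([N+](=O)[O-])c1)c1ccccc1` differs from compound 2 by hydrogen in place of 2-(dimethylamino)ethyl on a saturated chain carbon bound to a nitrogen on an aromatic ring and the same difference reads 3-(dimethylamino)propyl to methyl. Compound 1 also carries that methyl and stands at the limit > 100000 nM. A small rise toward lower toxicity in this assay is therefore expected, an estimated 1.7-fold higher number from compound 2 to compound 3 (0.22 log units; within the scatter), which would not clearly exceed the usual scatter. Compound 3 is estimated at 90000 nM, with an expected range of 40000 nM to 100000 nM.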

Compound 3, half-maximal cytotoxic concentration: > 100000 nM
Compound 3 ended at the assay's limit; the forecaster's own chance of this, stated with the estimate: 45%; at least 1.1-fold (0.04 log units) between middle value and limit.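

In this assay, exchanging 3-(dimethylamino)propyl for methyl gives an at least 1.8-fold higher number from compound 2 to compound 3 (0.26 log units; that floor lies within the scatter), and the floor of that step is all that can be read. Compound 3 stands at > 100000 nM, which is a limit of the assay and not a number. The step that adds nitro to the core of compound 1 cannot be read, since both values are limits.

As far as these compounds go, how large the chain step really is stays open because the readings stop at a ceiling: the limit of > 100000 nM in this assay, at which 2 of the 3 values shown sit. From the compounds shown here alone, what a shorter chain ending in a primary amine or a carboxylic acid would give at this place also remains open.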